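The compounds below may be only part of what the source reports. "The series", "measured", "known", "first", "only" and "open" are said of these compounds alone.

Compound 1 `Cc1nc(NC(C)C)nc(N[C@@H]2C[C@H](CO)[C@@H](O)[C@H]2O)c1-c1nc2ccccc2s1`, compound 2 `CCOC(=O)NCCNc1nc(C)c(-c2nc3ccccc3s2)c(N[C@@H]2C[C@H](CO)[C@@H](O)[C@H]2O)n1` and compound 3 `Cc1nc(Nc2nccs2)nc(N[C@@H]2C[C@H](CO)[C@@H](O)[C@H]2O)c1-c1nc2ccccc2s1` share one core and differ only in the group carried on a nitrogen on an aromatic ring. In an ADME assay on cells (Homo sapiens) for cytotoxicity, read by polymerase chain reaction, with a stated time of 3 days (on this read-out higher numbers stand for lower toxicity in this test and lower numbers for higher toxicity in this test), compound 1 gives 13000 nM. In this assay compound 2 gives 12000 nM and compound 3 gives 15000 nM. Each step between them stays within the scatter: a 1.1-fold lower number from compound 1 to compound 2 (0.03 log units; within the scatter), a 1.2-fold higher number from compound 1 to compound 3 (0.06 log units; within the scatter) and a 1.3-fold higher number from compound 2 to compound 3 (0.10 log units; within the scatter). Among the measured compounds shown here, compound 3 therefore sits together with compounds 1 and 2, with no step to either that rises beyond the scatter.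

Compound 4 `Cc1nc(NCc2ccncc2)nc(N[C@@H]2C[C@H](CO)[C@@H](O)[C@H]2O)c1-c1nc2ccccc2s1` takes the next exchange at the same position: (pyridin-4-yl)methyl in place of 1,3-thiazol-2-yl on a nitrogen on an aromatic ring. For the measured compounds named here, the two steps that bear on this position, the one from compound 1 to compound 3 and the one from compound 2 to compound 3, both replaced one group by another at this nitrogen and both stayed within the scatter. No step beyond the scatter is therefore expected from compound 3 to compound 4 in this assay, and the expected step is a 1.2-fold lower number from compound 3 to compound 4 (0.06 log units; within the scatter). Compound 4 is estimated at 13000 nM, with a range from 6000 nM to 28000 nM.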

Compound 4, half-maximal cytotoxic concentration: 7000 nM
The estimate for compound 4 lay 1.9-fold (0.27 log units) above the measured number; the measured number falls inside the stated range.
By their numbers in this assay, from the lowest: compounds 4, 2, 1 and 3 (each within the scatter of the next, the first and the last beyond it).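

Among the compounds shown here, at this nitrogen, (pyridin-4-yl)methyl in place of 1,3-thiazol-2-yl gives the first step in this assay that passes the scatter (a 2.1-fold lower number from compound 3 to compound 4 (0.33 log units; beyond the scatter)), and that step is modest. The steps from the other two compounds stay within the scatter (a 1.7-fold lower number from compound 2 to compound 4 (0.23 log units; within the scatter); a 1.9-fold lower number from compound 1 to compound 4 (0.27 log units; within the scatter)), so the position is not shown to be wholly indifferent, but only one of these three pairs separates. Nothing available accounts for this step.

The exchange swaps the five-membered ring for a six-membered ring and also places a saturated chain carbon on the nitrogen, and the compounds shown do not separate these two changes. Open, from the compounds shown here alone, is how pyridin-4-yl bound directly to the nitrogen, a benzyl group or a chain ending in an amine or a carboxylic acid would read at this position.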